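Chloro in place of methyl on the pendant phenyl ring

The source may report more compounds than this note shows. Statements on the series, on what has been measured and on what is new or still open speak of the compounds shown alone.

Three compounds share one core and differ only in the aryl group. For the measured compounds named here, in a functional assay on CHO cells for antagonist activity at adenosine receptor A2b (Homo sapiens), read by 33P incorporation, with a stated time of 20 min (on this read-out lower numbers stand for stronger inhibition and higher numbers for weaker inhibition), compound 3 `Cc1cccc(-c2nc3c(NC4CCCC4)ncnc3n2C)c1` gives 6030 nM, the only number among the values shown. Compound 1 `COc1ccc(-c2nc3c(NC4CCCC4)ncnc3n2C)cc1` reaches only the limit > 30000 nM. Compound 2 `Cn1c(-c2ccc(Cl)cc2)nc2c(NC3CCCC3)ncnc21` likewise stops at the limit > 30000 nM. Both sit at the limit of > 30000 nM in this assay, at which 2 of the 3 values shown sit. The steps of an at least 4.9-fold lower number from compound 1 to compound 3 (0.69 log units; beyond the scatter) and an at least 4.9-fold lower number from compound 2 to compound 3 (0.69 log units; beyond the scatter) show 3-methylphenyl giving a lower number than either 4-methoxyphenyl or 4-chlorophenyl. Compound 4 `Cn1c(-c2ccccc2Cl)nc2c(NC3CCCC3)ncnc21` carries 2-chlorophenyl in place of 3-methylphenyl on an aromatic carbon. Because an at least 4.9-fold lower number from compound 2 to compound 3 (0.69 log units; beyond the scatter) went the other way when a chlorophenyl was exchanged for the methylphenyl, a higher number is expected here, possibly again a limit. Compound 4 is therefore expected to give 12000 nM, between 3000 nM and 40000 nM, an expected step of a 2.0-fold higher number from compound 3 to compound 4 (0.30 log units; within the scatter).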

Compound 4, inhibition constant: > 30000 nM
Compound 4 gave a limit, no number; the forecaster's own chance of this, stated with the estimate: 40%; middle value at least 2.5-fold (0.39 log units) from the limit.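

In this assay, the exchange at this aromatic carbon gives an at least 4.9-fold higher number from compound 3 to compound 4 (0.69 log units; beyond the scatter), so 2-chlorophenyl, like the 4-chlorophenyl of compound 2, ends at a limit rather than a number. The steps from compound 1 and compound 2 to compound 4 join limit to limit and cannot be read. Among the aryl groups shown, only 3-methylphenyl gives a number: the limit of > 30000 nM in this assay, at which 3 of the 4 values shown sit.

The compounds shown leave open whether the methyl group itself or its place on the ring matters for compound 3. As far as these compounds go, how an amine or a carboxylic acid on the phenyl ring would read also stays open.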